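Cytotoxicity on Raji cells: a capped aryl series

A few compounds are considered here, and "the series" means these few. Any claim that something is new, unique, unknown or untested is made for them only; others in the source may bear on it.

Compound 1 `CC(C)N(Cc1cccc(OCCCCCC(=O)O)c1)C(=O)c1ccccc1` gives, in an ADME assay on Raji cells (Homo sapiens) for cytotoxicity, read by CellTiter-Glo and resazurin assay, with a stated time of 72 h (a lower number here means that less compound is needed, a higher number that more compound is needed for the effect), a value that is a limit of the assay, > 26000 nM. Compound 2 `CC(C)N(Cc1cccc(OCCCCCC(=O)O)c1)C(=O)c1ccc(-c2ccc3c(c2)OCCO3)cc1` gives in this assay a limit, > 21900 nM. Compound 3 `CC(C)N(Cc1cccc(OCCCCCC(=O)O)c1)C(=O)c1ccc(-c2cccc(OC(F)(F)F)c2)cc1` gives in this assay a limit, > 26000 nM.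

Compound 3 therefore stands at a limit, not at a number, and so do the other two compounds; two of the three values sit at the limit of > 26000 nM in this assay, at which 2 of the 3 values shown sit, and one at the limit of > 21900 nM in this assay, at which 1 of the 3 values shown sits. Within the data shown here, none of the measured steps can be read: a step that the two limits leave unreadable from compound 1 to compound 2, a step that the two limits leave unreadable from compound 1 to compound 3 and a step that the two limits leave unreadable from compound 2 to compound 3 are each unreadable because both ends are limits.

Compound 4 `COc1cc(F)cc(-c2ccc(C(=O)N(Cc3cccc(OCCCCCC(=O)O)c3)C(C)C)cc2)c1` is not yet measured. It differs from compound 3 by 3-fluoro-5-methoxyphenyl in place of 3-(trifluoromethoxy)phenyl on an aromatic carbon. Among the measured compounds shown here, the steps that bear on this change, from compound 1 to compound 2, from compound 1 to compound 3 and from compound 2 to compound 3, all vary the same aromatic carbon and all left the value at a limit, so no size or direction is readable from them, and no step beyond the scatter is expected in this assay for compound 4. The estimate for compound 4 is therefore 26000 nM, within 15000 nM to 60000 nM, which means an expected step of a number no higher from compound 3 to compound 4 (the limit leaves the size open) that is most likely again a limit rather than a number.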

Compound 4, half-maximal effective concentration: > 26000 nM
Compound 4 gave a limit, no number; the forecaster's own chance of this, stated with the estimate: 85%; the middle value sits exactly at the limit.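

No new step can be read: compound 4, like compound 1, compound 2 and compound 3, stands at a limit in this assay, so its steps from those three compounds stay unreadable. The compounds shown leave open at what concentration, if any, each would reach the half-maximal effect in this assay.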